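The source may report more compounds than this note shows. Statements on the series, on what has been measured and on what is new or still open speak of the compounds shown alone.

Of the compounds shown here, three have been tested in an assay on isolated protein for inhibition of thyroid hormone receptor beta (Homo sapiens), read by fluorescence polarization; a higher number here means a weaker inhibitor, a lower number a stronger inhibitor. Compound 1, with the structure `CS(=O)(=O)c1ccc(C(=O)N2CCC(C(=O)N(Cc3ccccc3)Cc3ccccc3)CC2)cc1[N+](=O)[O-]`, gives > 60000 nM in this assay; that is a limit of the assay, not a number. Compound 2, `CS(=O)(=O)c1ccc(C(=O)NCCCC(=O)N2CCC(c3ccccc3)CC2)cc1[N+](=O)[O-]`, gives > 60000 nM in this assay, again only a limit. Compound 3, `CN(Cc1cccc(F)c1)C(=O)CCCNC(=O)c1ccc(S(C)(=O)=O)c([N+](=O)[O-])c1`, gives > 60000 nM in this assay, also a limit rather than a measured number. So compound 1 stands at the edge of what the assay can report, where every value so far sits (the limit of > 60000 nM in this assay, at which 3 of the 3 values shown sit). Within the data shown here, no two of the measured compounds differ in only one place, so no single measured step exists. The compound still to be tested is compound 4, `CN(Cc1ccccc1)C(=O)C1CCN(C(=O)c2ccc(S(C)(=O)=O)c([N+](=O)[O-])c2)CC1`. It differs from compound 1 in one place: hydrogen in place of phenyl on a saturated chain carbon bound to an amide-type nitrogen. Because all values shown are limits (the limit of > 60000 nM in this assay, at which 3 of the 3 values shown sit), no direction can be read from a measured change. Compound 3 is the closest in shape to compound 4 among the measured compounds and also sits at a limit. The expected step that the limit leaves unreadable from compound 1 to compound 4 is none beyond the scatter. Compound 4 is estimated at 100000 nM, within 30000 nM to 400000 nM, and most likely the assay again reports only a limit.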

Compound 4, half-maximal inhibitory concentration: > 60000 nM
Compound 4 was reported as a limit; the forecaster's own chance of this, stated with the estimate: 85%; the middle value lies beyond the limit too.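

No step can be read from compound 1 to compound 4, because both are reported only as limits, not numbers: the limit of > 60000 nM in this assay, at which 4 of the 4 values shown sit. The compounds shown leave open which structural change, if any, would give a measurable value rather than another limit.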